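Halo swap on the aryl arm: cytotoxicity notes

The source may report more compounds than this note shows. Statements on the series, on what has been measured and on what is new or still open speak of the compounds shown alone.

Measured so far, in an ADME assay on Vero cells (Chlorocebus sabaeus) for cytotoxicity, read by MTT assay, with a stated time of 72 h; a lower number here means that less compound is tolerated, a higher number that more compound is tolerated:
- compound 1 `CC1(c2ccc(NC(c3ccc(Br)cc3)c3nnnn3C3CCCCC3)cc2)NC(=O)c2ccccc2N1`: > 400000 nM, a limit of this assay
- compound 2 `Nc1nc(-c2ccc(Cl)cc2)cc(-c2ccc(C3NC(=O)c4ccccc4N3)cc2)n1`: 323000 nM
- compound 3 `Nc1nc(-c2ccc(Br)cc2)cc(-c2ccc(C3NC(=O)c4ccccc4N3)cc2)n1`: > 400000 nM, a limit of this assay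

Two of the three values sit at the limit of this assay, (the limit of > 400000 nM in this assay, at which 2 of the 3 values shown sit). Only compound 2 returns a number. The step from compound 3 to compound 2 is the change (chloro in place of bromo on an aromatic carbon); it reads as an at least 1.2-fold lower number from compound 3 to compound 2 (0.09 log units; that floor lies within the scatter), and that size is a floor set by the limit of > 400000 nM in this assay, at which 2 of the 3 values shown sit, rather than a measured difference.

The same change is now to be made on the other core. Compound 4 `CC1(c2ccc(NC(c3ccc(Cl)cc3)c3nnnn3C3CCCCC3)cc2)NC(=O)c2ccccc2N1` differs from compound 1 by chloro in place of bromo on an aromatic carbon. The two place descriptions agree word for word, so this is the same change, made on a different scaffold; the difference between the core of compound 1 and the core of compound 3 is not broken down here.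

For compound 4 the step is expected to be a number no higher from compound 1 to compound 4 (the limit leaves the size open), which rests on compound 1 giving only a limit, > 400000 nM, and on the halogen swap from compound 3 to compound 2 having produced an at least 1.2-fold lower number from compound 3 to compound 2 (0.09 log units; that floor lies within the scatter). In this assay compound 4 is therefore expected to give about 400000 nM, estimated between 200000 nM and 800000 nM, with a real chance that only a limit is returned.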

Compound 4, half-maximal cytotoxic concentration: > 400000 nM
Compound 4: no number, only a limit; the forecaster's own chance of this, stated with the estimate: 60%; the middle value lies on the limit itself.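

Compound 1 and compound 4 both return only a limit, so no step can be read for the change from 4-bromophenyl to 4-chlorophenyl on this core: the limit of > 400000 nM in this assay, at which 3 of the 4 values shown sit.

The compounds shown leave open whether chloro and bromo differ at all on the core of compound 1 in this assay, and so whether the change behaves alike on the two cores.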